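A few compounds are considered here, and "the series" means these few. Any claim that something is new, unique, unknown or untested is made for them only; others in the source may bear on it.

The measured compounds:

compound 1, `COC(=O)C1=C(C)N=C(C)/C(=C(\O)OC)C1c1cc([N+](=O)[O-])ccc1O`, gives 100 nM in a functional assay (muscle tissue) with Cavia porcellus as the target; on this read-out lower numbers stand for an effect already at smaller amounts and higher numbers for an effect only at larger amounts of compound
compound 2, `COC(=O)C1=C(C)N=C(C)/C(=C(\O)OC)C1c1cccc(Cl)c1Cl`, gives 19.1 nM in this assay
compound 3, `COC(=O)C1=C(C)N=C(C)/C(=C(\O)OC)C1c1cc(OC)c(OC)cc1OC`, gives 1000000 nM in this assay

All three share one core and differ only in the aryl group on a saturated ring carbon of that core. In this assay compound 2 stands at the lowest number of the three; the gap to compound 1 and the far larger gap to compound 3 both lie beyond the usual scatter, so compound 2 is the most potent of the set.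

Compound 4, `COC(=O)C1=C(C)N=C(C)/C(=C(\O)OC)C1c1ccccc1Br`, has not yet been measured. Its change relative to compound 2 is: 2-bromophenyl in place of 2,3-dichlorophenyl on a saturated ring carbon. Among the measured compounds shown here, no measured pair in this set shows this exact change, so the expectation rests on the three values alone. The step that the estimate implies, a 2.1-fold higher number from compound 2 to compound 4 (0.32 log units; beyond the scatter), is expected to be small and toward a higher number, near the edge of the scatter. Compound 4 is estimated to give 40 nM in this assay, with a range from 8 nM to 200 nM.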

Compound 4, half-maximal effective concentration: 7.59 nM
The estimate for compound 4 lay 5.3-fold (0.72 log units) above the measured number; the measured number lies below the stated range.
By their numbers in this assay, from the lowest: compound 4; then compound 2; then compound 1; then compound 3.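

Replacing 2,3-dichlorophenyl with 2-bromophenyl on the saturated ring carbon gives a 2.5-fold lower number from compound 2 to compound 4 (0.40 log units; beyond the scatter) in this assay and leaves compound 4 with the lowest number of the four. This position therefore keeps a low number with a single bromine on the aryl ring, and the two chlorines of compound 2 are not needed for it. No measurement shown here explains why the number falls with this change.

As far as these compounds go, the change removes both chlorines and adds a bromine in one step, so the part of it that matters stays open, and an unsubstituted phenyl ring would be one way to separate these parts. From the compounds shown here alone, how this position responds to an aryl ring carrying an amine or a carboxylic acid also remains unknown.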